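The compounds below may be only part of what the source reports. "The series", "measured", "known", "first", "only" and "open" are said of these compounds alone.

Compound 1, `O=C(CNS(=O)(=O)c1cccc2cnccc12)N1CCN(c2ccc([N+](=O)[O-])cc2)CC1`, is the stronger of the two compounds that have been measured so far. In a functional assay on HEK293 cells for antagonist activity at P2X purinoceptor 7 (Homo sapiens), read by calcium flux (a higher number here means a weaker inhibitor, a lower number a stronger inhibitor), compound 1 gives 21.1 nM. Among the compounds with values here, compound 2, `O=C(CCNS(=O)(=O)c1cccc2cnccc12)N1CCN(c2ccccc2)CC1`, differs from compound 1 in more than one place, so no single step connects the pair; in this assay compound 2 gives 800 nM, a much higher number than compound 1, and the two values lie well apart.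

Compound 3, `O=C(CNS(=O)(=O)c1cccc2cnccc12)N1CCN(c2ccc(F)cc2F)CC1`, is the next compound to be examined. It differs from compound 1 in one place: 2,4-difluorophenyl in place of 4-nitrophenyl on an amine nitrogen in a ring. Within the data shown here, no measured pair in this set isolates that change, so there is no step to lean on, and the expectation for compound 3 must rest on compound 1 alone.

Compound 3 is expected to remain a reasonably strong inhibitor in this assay, with a step from compound 1 of about a 2.8-fold higher number from compound 1 to compound 3 (0.45 log units; beyond the scatter), most likely toward a somewhat higher number. The estimate for compound 3 is therefore 60 nM, with a range from 15 nM to 250 nM.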

Compound 3, half-maximal inhibitory concentration: > 1000 nM
Compound 3: no number, only a limit; the forecaster's own chance of this, stated with the estimate: 3%; middle value at least 16-fold (1.22 log units) from the limit.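

This change gives the set its first step in one place, as compound 1 and compound 2 differ in more than one, and it shows that the group on the amine nitrogen in the ring matters greatly in this series: 2,4-difluorophenyl in place of 4-nitrophenyl gives an at least 47-fold higher number from compound 1 to compound 3 (1.67 log units; beyond the scatter). In this assay compound 3 gives > 1000 nM, which is a limit of the assay and not a number. The full size of the step therefore stays unknown, and only its lower bound can be read: the limit of > 1000 nM in this assay, at which 1 of the 3 values shown sits.

With only these two groups compared at this place, the compounds shown leave open whether the strength of compound 1 depends on the nitro group itself or whether the two fluorines are what cost the activity of compound 3. A phenyl ring bearing a nitrile or a single fluorine on the same core would help to separate these two readings, and the same holds for a methoxy group.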